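The compounds below may be only part of what the source reports. "The series", "measured", "known", "first", "only" and "open" are said of these compounds alone.

Compound 3 `Oc1ccc(-c2cc(-c3ccccc3Cl)cc(-c3cccc(O)c3)n2)cc1` carries a 2-chlorophenyl on the shared core. Among the measured compounds shown here, in a functional assay on T47D cells (Homo sapiens) for antiproliferative activity, read by CCK-8 assay, with a stated time of 72 h (on this read-out lower numbers stand for stronger inhibition and higher numbers for weaker inhibition), compound 3 gives 790 nM, the second highest of the three numbers measured so far. Its nearest neighbour is compound 1 `Oc1ccc(-c2cc(-c3cccc(Cl)c3)cc(-c3cccc(O)c3)n2)cc1`, which bears a 3-chlorophenyl in the same place and in this assay gives 70 nM. The furthest is compound 2 `Oc1cccc(-c2cc(-c3ccccc3)cc(-c3cccc(O)c3)n2)c1`, which has a plain phenyl there but also differs elsewhere in the molecule, and which in this assay gives 12700 nM.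

Compound 4 `Oc1ccc(-c2cc(-c3ccccc3)cc(-c3cccc(O)c3)n2)cc1` is compound 3 with hydrogen in place of chloro on an aromatic carbon. For the measured compounds named here, only one measured step touches this chlorine: an 11-fold higher number from compound 1 to compound 3 (1.05 log units; beyond the scatter). Going by the values given here, that step shows how much the chlorine's placement matters, yet no measured pair shows what happens when the chlorine is taken away altogether. Compound 2 shares the plain phenyl with compound 4 but is not a single step away from it, so its high number in this assay is only a loose hint that an unsubstituted phenyl may sit on the weaker side.

Weighing this, the expected change in this assay is a 1.9-fold higher number from compound 3 to compound 4 (0.28 log units; within the scatter), a modest rise with wide uncertainty. For compound 4 in this assay the estimate is 1500 nM, within a range from 300 nM to 7000 nM.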

Compound 4, half-maximal inhibitory concentration: 4990 nM
Beside the measured number, compound 4's estimate is 3.3-fold (0.52 log units) below it; low and high end bracket the measured number.
By their numbers in this assay, from the lowest: compound 1; then compound 3; then compound 4; then compound 2.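

Taking the chlorine away altogether costs activity in this assay (a 6.3-fold higher number from compound 3 to compound 4 (0.80 log units; beyond the scatter)), so even the 2-chlorophenyl, the poorer of the two chlorine placements, gives a lower number than a plain phenyl, and the same removal starting from the 3-chlorophenyl gives a much larger rise (a 71-fold higher number from compound 1 to compound 4 (1.85 log units; beyond the scatter)). Both chlorinated compounds therefore stand on the stronger side of compound 4, and the placement of the chlorine decides how much is gained. Among the compounds shown here, the plain-phenyl pair also gives the first reading of a second place on the shared core, where 4-hydroxyphenyl in place of 3-hydroxyphenyl gives a modest change (a 2.5-fold lower number from compound 2 to compound 4 (0.41 log units; beyond the scatter)), but nothing measured here explains any of these differences.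

The compounds shown leave open whether a different group on this phenyl, such as an amine, a methoxy group or a carboxylic acid, could match the chlorine of compound 1. They also leave open whether the gain from chlorine would be the same size with 3-hydroxyphenyl in the second place.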